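The source may report more compounds than this note shows. Statements on the series, on what has been measured and on what is new or still open speak of the compounds shown alone.

Measured in a functional assay on MDA-MB-231 cells (Homo sapiens) for cytotoxicity, read by MTT assay, with a stated time of 72 h; on this read-out lower numbers stand for stronger inhibition and higher numbers for weaker inhibition:
- Compound 1, `O=C(CN1CCN(c2nnc(Cc3ccccc3)c3ccccc23)CC1)Nc1c(F)cccc1F`: 5490 nM
- Compound 2, `Cc1ccccc1NC(=O)CN1CCN(c2nnc(Cc3ccccc3)c3ccccc23)CC1`: 17300 nM

Of these two compounds, compound 2 stands highest at 17300 nM, which makes it the weaker inhibitor. The next compound, compound 3, `O=C(CN1CCN(c2nnc(Cc3ccccc3)c3ccccc23)CC1)Nc1cccc(Br)c1`, has not yet been measured. It keeps the shared core and carries 3-bromophenyl in place of 2-methylphenyl on an amide-type nitrogen.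

Among the compounds with values here, only one measured step touches this place, a 3.2-fold higher number from compound 1 to compound 2 (0.50 log units; beyond the scatter). It is modest but beyond the scatter, and it shows that changing this aryl group can move the number in this assay. Within the data shown here, it involves a different group, however, and the data hold no bromine-bearing compound, so it offers only a rough guide to size. Among the measured compounds shown here, the only other aryl group tested gives a lower number than compound 2, so a modest step downward is expected, though no change beyond the scatter remains possible. The estimate amounts to a 1.9-fold lower number from compound 2 to compound 3 (0.28 log units; within the scatter), an expected step of similar modest size. For compound 3 the expected value is 9000 nM, with an estimated range from 3000 nM to 25000 nM.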

Compound 3, half-maximal inhibitory concentration: 3880 nM
For compound 3 the middle estimate is 2.3-fold (0.37 log units) above the measured one, and the stated range covers the measured number.
By their numbers in this assay, from the lowest: compounds 3 and 1 (each within the scatter of the next); then compound 2.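

In this assay, the change on the amide-type nitrogen gives a 4.5-fold lower number from compound 2 to compound 3 (0.65 log units; beyond the scatter), a modest step beyond the scatter. Compound 2 now stands apart from two compounds with different aryl groups, rather than from compound 1 alone, while the step of a 1.4-fold lower number from compound 1 to compound 3 (0.15 log units; within the scatter) shows that 3-bromophenyl and 2,6-difluorophenyl cannot be told apart in this assay, even though the two groups differ in their halogen and in its placement on the ring. Among these three compounds, the two with a halogen-bearing aryl group lie together and the one with 2-methylphenyl lies apart, with no compound going against this, but nothing at hand accounts for the difference.

The compounds shown leave open whether the gap follows the swap of methyl for a halogen or the place of the group on the ring, since compounds 2 and 3 differ in both, and a 3-methylphenyl or 2-bromophenyl group would separate the two. They also leave open how this position responds to a group of another kind on the ring, such as an amine or a carboxylic acid.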